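The source may report more compounds than this note shows. Statements on the series, on what has been measured and on what is new or still open speak of the compounds shown alone.

In a functional assay on SK-N-SH cells (Homo sapiens) for inhibition, read by MTT assay (a lower number here means a stronger inhibitor, a higher number a weaker inhibitor), the three measured compounds give:

Compound 1, `O=C(CBr)Nc1ccc(C(=O)/C=C/c2cn(Cc3ccc(Br)cc3)nn2)cc1`: 8300 nM
Compound 2, `CCCCCCCCn1cc(/C=C/C(=O)c2ccc(NC(=O)CBr)cc2)nn1`: 8460 nM
Compound 3, `CCCCCCCCn1cc(/C=C/C(=O)c2ccc(NC(=O)CN3CCN(c4ccccc4OC)CC3)cc2)nn1`: 21500 nM

Compound 2 stands second highest of these three numbers. Its nearest neighbour is compound 1, and the step of a 1.0-fold higher number from compound 1 to compound 2 (0.01 log units; within the scatter) lies within the scatter, so the two are indistinguishable here. Its furthest neighbour is compound 3, whose number is higher than that of compound 2 by more than the scatter.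

Compound 4, `CCCCCCCCn1cc(/C=C/C(=O)c2ccc(N)cc2)nn1`, is the unmeasured compound. It differs from compound 2 in one place: hydrogen in place of (bromomethyl)carbonyl on a nitrogen on an aromatic ring. Among the compounds with values here, the only measured step, between compound 1 and compound 2, concerns the other end of the shared core and was within the scatter, so it says nothing about this change. Within the data shown here, the values of compound 2 and compound 3 show that exchanging the bromomethyl for a larger group gave a higher number in this assay, but no step is computed for that pair and the change to compound 4 removes the whole (bromomethyl)carbonyl rather than replacing it. The expectation for compound 4 therefore rests on thin ground: a higher number is expected, the step of a 3.0-fold higher number from compound 2 to compound 4 (0.47 log units; beyond the scatter), with a wide range around the estimate 25000 nM, from 8000 nM to 80000 nM.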

Compound 4, half-maximal inhibitory concentration: 28800 nM
Estimate against measurement, compound 4: 1.2-fold (0.06 log units) below; measured number inside the range.
By their numbers in this assay, from the lowest: compounds 1 and 2 (each within the scatter of the next); then compounds 3 and 4 (each within the scatter of the next).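

Replacing the (bromomethyl)carbonyl on the nitrogen on an aromatic ring with hydrogen gives, in this assay, a 3.4-fold higher number from compound 2 to compound 4 (0.53 log units; beyond the scatter), so this nitrogen is a place where a change moves the number beyond the scatter, and the free amino compound is the weaker inhibitor of the pair. Compound 4 at 28800 nM and compound 3 at 21500 nM lie within the scatter of each other, so the bare amino group and the larger group carried on this nitrogen in compound 3 cannot be told apart here, while compound 2, which keeps the bromomethyl, stands apart from both. Nothing available here gives a measured reason for this shift.

Going by these compounds, what remains open is whether the bromine or the carbonyl carries the difference, since an acetyl group on this nitrogen, with a hydrogen where the bromine stands, or a chloroacetyl group would be needed to separate the two. On these data alone, it is also open whether the same step would hold on the core of compound 1, with its 4-bromophenyl in place of the heptyl.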